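The source may report more compounds than this note shows. Statements on the series, on what has been measured and on what is new or still open speak of the compounds shown alone.

Working notes on a bis(propargyloxy)aryl pyrimidine series tested in an assay on BTI-TN-5B1-4 cells for inhibition of Amine oxidase [flavin-containing] A (Homo sapiens), read by fluorescence and Amplex Red, using microsomes, with a stated time of 30 min; a higher number here means a weaker inhibitor, a lower number a stronger inhibitor. Compound 1 `C#CCOc1cccc(-c2cc(-c3cccc(OCC#C)c3)nc(N)n2)c1` gives "not active" (no number reported), so no number stands for it. Compound 2 `C#CCOc1ccc(-c2cc(-c3ccc(OCC#C)cc3)nc(C)n2)cc1` gives 34200 nM, the highest of the two numbers available, and compound 3 `C#CCOc1ccc(-c2cc(-c3ccc(OCC#C)cc3)nc(N)n2)cc1` gives 32100 nM. Within the data shown here, the single one-point step, a 1.1-fold lower number from compound 2 to compound 3 (0.03 log units; within the scatter), exchanges the substituent on the shared core and leaves the number essentially unchanged.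

Compound 4 `C#CCOc1ccc(-c2cc(-c3ccc(OCC#C)c(OCC)c3)nc(C)n2)cc1` differs from compound 2 by ethoxy in place of hydrogen on an aromatic carbon. Among the measured compounds shown here, no measured step touches this site: the only step, from compound 2 to compound 3, alters the core substituent and therefore gives no direct guidance, beyond showing that a small change elsewhere in the molecule stayed within the scatter. With compound 2 already near the weak end of the range in this assay, the expectation is a number close to that of compound 2, with no step beyond the scatter: a 1.0-fold higher number from compound 2 to compound 4 (0.01 log units; within the scatter) is the estimated step. Compound 4 is therefore expected to give about 35000 nM in this assay, within a range of 12000 nM to 100000 nM.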

Compound 4, half-maximal inhibitory concentration: "not active" (no number reported)
For compound 4 the study gives words and no number, so the estimate cannot be set against anything.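

In this assay, among these compounds, compound 4 gives "not active" (no number reported) and no step from compound 2 to compound 4 can be read. Nothing measured here bears on this result. The compounds shown leave open how ethoxy in place of hydrogen on this aromatic carbon shifts the number.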